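Replacing 3-carbamoylphenyl with 4-(methylsulfonyl)phenyl: clearance notes

The source may report more compounds than this note shows. Statements on the series, on what has been measured and on what is new or still open speak of the compounds shown alone.

Measured in an ADME assay (liver) for metabolic stability, with Liver microsome (Homo sapiens) as the target, using microsomes and NADPH, with a stated time of 30 min, tested at 1 uM; a lower number here means slower removal, a higher number faster removal of the compound:
- compound 1 `Nc1ccc(S(=O)(=O)N2CCN(c3ncc(C(O)(C(F)(F)F)C(F)(F)F)cc3C3CC3)CC2)cn1`: 38 mL.min-1.g-1
- compound 2 `Nc1ccc(S(=O)(=O)N2CCN(c3ncc(C(O)(C(F)(F)F)C(F)(F)F)cc3C#CCCO)CC2)cn1`: < 14 mL.min-1.g-1 (a limit of the assay)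
- compound 3 `NC(=O)c1cccc(-c2cc(C(O)(C(F)(F)F)C(F)(F)F)cnc2N2CCN(S(=O)(=O)c3ccc(N)nc3)CC2)c1`: 17 mL.min-1.g-1

Of the two results that are true numbers, compound 3 holds the lower, with 17 mL.min-1.g-1, and compound 1 stands higher at 38 mL.min-1.g-1. The result for compound 2 is a limit and not a number.

Compound 4 `CS(=O)(=O)c1ccc(-c2cc(C(O)(C(F)(F)F)C(F)(F)F)cnc2N2CCN(S(=O)(=O)c3ccc(N)nc3)CC2)cc1` carries 4-(methylsulfonyl)phenyl in place of 3-carbamoylphenyl on an aromatic carbon. Among the measured compounds shown here, no measured step involves the entering group. The nearest guide is the replacement of cyclopropyl by the group that now leaves, which gave a 2.2-fold lower number from compound 1 to compound 3 (0.35 log units; beyond the scatter). The replacement of cyclopropyl by 4-hydroxybut-1-yn-1-yl gave an at least 2.7-fold lower number from compound 1 to compound 2 (0.43 log units; beyond the scatter), and the exchange of those two replacements gave an at least 1.2-fold higher number from compound 2 to compound 3 (0.08 log units; that floor lies within the scatter). Both measured replacements of cyclopropyl were modest, and the change to compound 4 keeps a six-membered aromatic ring of carbon only at the same place. Little room remains under compound 3 in this assay, given (the limit of < 14 mL.min-1.g-1 in this assay, at which 1 of the 3 values shown sits).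

No step beyond the scatter is therefore expected, and the estimated step is a 1.1-fold higher number from compound 3 to compound 4 (0.02 log units; within the scatter). Compound 4 is expected at 18 mL.min-1.g-1, with an estimated range of 13 mL.min-1.g-1 to 34 mL.min-1.g-1.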

Compound 4, intrinsic clearance in microsomes: 32 mL.min-1.g-1
Compound 4: the middle estimate sits 1.8-fold (0.25 log units) below what was measured; the range from low to high includes it.
By their numbers in this assay, from the lowest: compounds 3, 4 and 1 (each within the scatter of the next, the first and the last beyond it). At a limit, below all of these: compound 2.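

In this assay, the exchange of 3-carbamoylphenyl for 4-(methylsulfonyl)phenyl at this aromatic carbon gives a 1.9-fold higher number from compound 3 to compound 4 (0.27 log units; within the scatter), and the exchange of cyclopropyl for 4-(methylsulfonyl)phenyl gives a 1.2-fold lower number from compound 1 to compound 4 (0.07 log units; within the scatter). A six-membered aromatic ring of carbon only at this place therefore does not by itself set a compound apart from the cyclopropyl compound: the earlier step from cyclopropyl to 3-carbamoylphenyl lay beyond the scatter and this one does not, so what the ring carries can matter to the read-out. Replacing 4-hydroxybut-1-yn-1-yl, whose compound gives a limit and not a number, yields an at least 2.2-fold higher number from compound 2 to compound 4 (0.35 log units; beyond the scatter), which shows that the two groups do not give equivalent results at this place.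

From the compounds shown here alone, the two aryl groups differ both in their substituent and in where it stands on the ring, so it stays open how 4-carbamoylphenyl, 3-(methylsulfonyl)phenyl or an unsubstituted phenyl would compare. Any result under that of compound 3 could be read over only a short span: the limit of < 14 mL.min-1.g-1 in this assay, at which 1 of the 4 values shown sits.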